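Fluoro for Nitro on a Benzothiazole Enaminone Series

A few compounds are considered here, and "the series" means these few. Any claim that something is new, unique, unknown or untested is made for them only; others in the source may bear on it.

The measured compounds and their values:

Compound 1, `COc1ccc2nc(-c3ccc(N/C=C\C(=O)c4ccc(OC)c(F)c4)c(C)c3)sc2c1`: 1400 nM
Compound 2, `COc1ccc(C(=O)/C=C\Nc2ccc(-c3nc4cc(OC)c(OC)c(OC)c4s3)cc2)cc1[N+](=O)[O-]`: 21200 nM
Compound 3, `COc1ccc2nc(-c3ccc(N/C=C\C(=O)c4ccc(OC)c([N+](=O)[O-])c4)c(C)c3)sc2c1`: 13600 nM

Of the compounds shown here, three have been tested in a functional assay on A549 cells (Homo sapiens) for antiproliferative activity, read by sulforhodamine B assay, with a stated time of 48 h; a higher number here means a weaker inhibitor, a lower number a stronger inhibitor. Compound 1, `COc1ccc2nc(-c3ccc(N/C=C\C(=O)c4ccc(OC)c(F)c4)c(C)c3)sc2c1`, gives 1400 nM in this assay, the lowest of the three numbers. Compound 3, `COc1ccc2nc(-c3ccc(N/C=C\C(=O)c4ccc(OC)c([N+](=O)[O-])c4)c(C)c3)sc2c1`, gives 13600 nM, and compound 2, `COc1ccc(C(=O)/C=C\Nc2ccc(-c3nc4cc(OC)c(OC)c(OC)c4s3)cc2)cc1[N+](=O)[O-]`, gives 21200 nM, the highest number; compound 2 and compound 3 lie within the scatter of each other, while compound 2 stands well beyond compound 1.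

Compound 3 and compound 1 differ in one place, (fluoro in place of nitro on an aromatic carbon), and the step is a 9.7-fold lower number from compound 3 to compound 1 (0.99 log units; beyond the scatter). Compound 2 differs from compound 3 in its core; that difference is not broken down here.

Compound 4, `COc1ccc(C(=O)/C=C\Nc2ccc(-c3nc4cc(OC)c(OC)c(OC)c4s3)cc2)cc1F`, has not yet been measured. It relates to compound 2 by the same change, (fluoro in place of nitro on an aromatic carbon), at the same place. Among the compounds with values here, a comparable step is expected, since the only direct precedent for this change is the one from compound 3 to compound 1, measured as a 9.7-fold lower number from compound 3 to compound 1 (0.99 log units; beyond the scatter); the different core of compound 2 leaves room for the size to vary. In this assay compound 4 is therefore expected to give about 2500 nM, most plausibly between 800 nM and 8000 nM. That estimate means a step of an 8.5-fold lower number from compound 2 to compound 4 (0.93 log units; beyond the scatter).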

Compound 4, half-maximal inhibitory concentration: 15500 nM
The estimate for compound 4 lay 6.2-fold (0.79 log units) below the measured number; measured number above the stated range.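

In this assay, putting fluoro in place of nitro on the core of the trimethoxy-bearing pair gives a 1.4-fold lower number from compound 2 to compound 4 (0.14 log units; within the scatter), and so the large step seen on the other core does not carry over to this one: the same change on two cores in this assay, a 9.7-fold lower number (0.99 log units; beyond the scatter) from compound 3 to compound 1 and a 1.4-fold lower number (0.14 log units; within the scatter) from compound 2 to compound 4, 7.1-fold (0.85 log units) apart, beyond the scatter of two such steps For this series, then, the size of the step from the 4-methoxy-3-nitrophenyl group to the 3-fluoro-4-methoxyphenyl group cannot be taken from one core and applied to another, even though the change and its place on the ring are the same in both pairs. The result does not show why the two steps differ, since the two cores differ from each other in more than one place and two pairs cannot show which of those differences matters, nor does it say how the change would behave on any third core.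

The compounds shown leave open whether a core carrying only some of these differences would show the large step, the small one or something in between. They also leave open whether other groups at this place, such as chloro, a nitrile or an amine, would depend on the core in the same way.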